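A few compounds are considered here, and "the series" means these few. Any claim that something is new, unique, unknown or untested is made for them only; others in the source may bear on it.

In a functional assay on BT-474 cells (Homo sapiens) for inhibition, read by fluorescence, with a stated time of 72 h (a higher number here means a weaker inhibitor of growth, a lower number a stronger inhibitor of growth), three compounds built on a shared core have been measured. Compound 1 `CCCCCCn1cnc2c(Nc3cc(OC)cc(OC)c3)nc(N[C@H]3CC[C@H](N)CC3)nc21` gives 3700 nM, compound 2 `CCCCCCn1cnc2c(Nc3ccc(O)cc3)nc(N[C@H]3CC[C@H](N)CC3)nc21` gives 7700 nM, and compound 3 `CCCCCCn1cnc2c(Nc3cccc(Cl)c3)nc(N[C@H]3CC[C@H](N)CC3)nc21` gives 5100 nM. Compound 3 stands close to both of the others, with a 1.4-fold higher number from compound 1 to compound 3 (0.14 log units; within the scatter) and a 1.5-fold lower number from compound 2 to compound 3 (0.18 log units; within the scatter). The largest gap in the set is modest, at a 2.1-fold higher number from compound 1 to compound 2 (0.32 log units; beyond the scatter).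

Compound 4 `CCCCn1cnc2c(Nc3cccc(Cl)c3)nc(N[C@H]3CC[C@H](N)CC3)nc21` keeps the 3-chlorophenyl group of compound 3 and changes the chain instead: hydrogen in place of ethyl on a saturated chain carbon, four bonds along the chain from an aromatic nitrogen. Within the data shown here, none of the measured steps touches this chain, as all three exchange the group on a nitrogen on an aromatic ring. They therefore offer only a sense of scale, and the data give no direction for the chain change. Given the small size of a 1.4-fold higher number from compound 1 to compound 3 (0.14 log units; within the scatter) and of a 1.5-fold lower number from compound 2 to compound 3 (0.18 log units; within the scatter), no step beyond the scatter is expected in this assay, though this remains uncertain. The estimated step is a 1.1-fold higher number from compound 3 to compound 4 (0.03 log units; within the scatter). Compound 4 is expected at 5500 nM, within an estimated range of 2500 nM to 12000 nM.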

Compound 4, concentration for 50% growth inhibition: 5100 nM
Beside the measured number, compound 4's estimate is 1.1-fold (0.03 log units) above it; measured number inside the range.
By their numbers in this assay, from the lowest: compounds 1, 3, 4 and 2 (each within the scatter of the next, the first and the last beyond it).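

Hydrogen in place of ethyl on a saturated chain carbon, four bonds along the chain from an aromatic nitrogen, gives no change at the digits printed from compound 3 to compound 4 (within the scatter) in this assay. Among these compounds, this is the first reading of the chain, as every earlier step exchanged the group on a nitrogen on an aromatic ring, and it shows that, with the 3-chlorophenyl group held in place, this pair of compounds does not separate on the loss of those two carbons. No measurement shown here accounts for this result.

Among the compounds shown here, whether the chain change reads the same way with the 3,5-dimethoxyphenyl or 4-hydroxyphenyl group stays open, since it is seen only with the 3-chlorophenyl group. Also open, going by these compounds, is what a longer chain, a much shorter one such as methyl, or a chain ending in an amine or a carboxylic acid would give here.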